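From 3-chlorophenyl to 3,5-dichlorophenyl in compound 4

The compounds below may be only part of what the source reports. "The series", "measured", "known", "first", "only" and "open" are said of these compounds alone.

Of the compounds shown here, three have been read so far in an ADME assay on HS27 cells (Homo sapiens) for cytotoxicity, read by MTT assay, with a stated time of 24 h; a higher number here means a weaker inhibitor of growth, a lower number a stronger inhibitor of growth. Compound 1 (`Cc1ccc(NC(=O)C2(C)CCc3c(C)c(O)c(C)c(C)c3O2)cc1NC(=O)c1cnoc1C`) gives > 30000 nM, which is a limit and not a number. Compound 2 (`Cc1ccc(NC(=O)Nc2ccc(Cl)c(Cl)c2)cc1NC(=O)c1cnoc1C`) gives > 30000 nM, also a limit. Compound 3 (`Cc1cc(NC(=O)Nc2cccc(Cl)c2)ccc1NC(=O)c1cnoc1C`) gives > 30000 nM, again a limit. Compound 3 therefore has no exact value, and the whole set stands as the limit of > 30000 nM in this assay, at which 3 of the 3 values shown sit.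

Compound 4 (`Cc1cc(NC(=O)Nc2cc(Cl)cc(Cl)c2)ccc1NC(=O)c1cnoc1C`) differs from compound 3 by a single change: chloro in place of hydrogen on an aromatic carbon, which turns 3-chlorophenyl into 3,5-dichlorophenyl (chloro in place of hydrogen on an aromatic carbon). The new chloro sits meta to a chloro group and meta to a large group.

For the measured compounds named here, no pair of measured compounds differs in one place, so no measured step gives a size for this change. The expectation in this assay is for no step beyond the scatter, with a modest strengthening as the main alternative. Compound 2, also a dichlorophenyl compound, reads > 30000 nM, a limit, and this supports that expectation. The step expected is a number no higher from compound 3 to compound 4 (the limit leaves the size open). For compound 4 the estimated value is 30000 nM, with an expected range from 12000 nM to 60000 nM.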

Compound 4, concentration for 50% growth inhibition: > 30000 nM
Compound 4: only a limit was reported (the forecaster's own chance of this, stated with the estimate: 80%); the middle value sits exactly at the limit.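

No step can be read between compound 3 and compound 4 in this assay, as each gives only a limit and not a number: the limit of > 30000 nM in this assay, at which 4 of the 4 values shown sit.

The compounds shown leave open at what concentration any of them would inhibit growth in this read-out, and whether chloro in place of hydrogen on an aromatic carbon changes that concentration at all.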